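A Flat Series Meets a 4-Methylphenyl Group

The source may report more compounds than this note shows. Statements on the series, on what has been measured and on what is new or still open speak of the compounds shown alone.

Compounds measured in a functional assay on B16-F10 cells (Mus musculus) for cytotoxicity; a lower number here means a stronger inhibitor, a higher number a weaker inhibitor:
- compound 1 `O=c1oc2ccccc2c2nc3c(ccc4cc[nH]c43)c(-c3ccccn3)c12` gives 70700 nM
- compound 2 `O=c1oc2ccccc2c2nc3c(ccc4cc[nH]c43)c(-c3ccc(O)cc3)c12` gives 70700 nM
- compound 3 `O=c1oc2ccccc2c2nc3c(ccc4cc[nH]c43)c(-c3ccc(Cl)cc3Cl)c12` gives 70700 nM

Compound 3 stands level with compounds 1 and 2, so these three compounds offer no ranking. The next compound keeps the shared core and alters only the group on one aromatic carbon. In compound 4 `Cc1ccc(-c2c3ccc4cc[nH]c4c3nc3c2c(=O)oc2ccccc23)cc1`, 4-methylphenyl takes the place of 2,4-dichlorophenyl: 4-methylphenyl in place of 2,4-dichlorophenyl on an aromatic carbon.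

All three measured steps changed the group on this same carbon. Replacing pyridin-2-yl with 4-hydroxyphenyl gave no change at the digits printed from compound 1 to compound 2 (within the scatter). Replacing pyridin-2-yl with 2,4-dichlorophenyl gave no change at the digits printed from compound 1 to compound 3 (within the scatter). Replacing 4-hydroxyphenyl with 2,4-dichlorophenyl gave no change at the digits printed from compound 2 to compound 3 (within the scatter). None of these swaps moved the number, so no step beyond the scatter is expected in this assay, and no direction can be favoured. The expected step is no change at the digits printed from compound 3 to compound 4 (within the scatter). Compound 4 is estimated at 70700 nM, with an expected range of 30000 nM to 90000 nM.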

Compound 4, half-maximal inhibitory concentration: 70700 nM
Compound 4: the middle estimate sits on the measured number at the digits printed, within the range that was stated.
By their numbers in this assay, from the lowest: compounds 1, 2, 3 and 4 (each within the scatter of the next).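

In this assay a ring carrying only a methyl group behaves like the ring carrying two chlorines, with no change at the digits printed from compound 3 to compound 4 (within the scatter) for this swap. Methyl in place of hydroxy gives no change at the digits printed from compound 2 to compound 4 (within the scatter) and 4-methylphenyl in place of pyridin-2-yl gives no change at the digits printed from compound 1 to compound 4 (within the scatter) so a group made of carbon alone now joins the three earlier groups at the same level on this aromatic carbon. Nothing available explains why these four groups give the same number.

The compounds shown leave open whether any group on this carbon can move the number at all, for example a ring bearing an amine or a carboxylic acid, or a longer chain in place of the ring. They also leave open whether a change elsewhere on the shared core would do so.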